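The compounds below may be only part of what the source reports. "The series", "measured", "known", "first", "only" and "open" are said of these compounds alone.

The measured compounds in a functional assay (trachea) with Cavia porcellus as the target; on this read-out higher numbers stand for an effect only at larger amounts of compound and lower numbers for an effect already at smaller amounts:
compound 1 `CCCn1c(=O)n(CC)c(=O)c2[nH]cnc21` gives 1300 nM
compound 2 `CCCn1c(=O)n(CCC(N)=O)c(=O)c2[nH]cnc21` gives 13100 nM
compound 3 `CCCn1c(=O)n(CCOC)c(=O)c2[nH]cnc21` gives 700 nM

Compound 2 has the highest number of the three in this assay, and its distance to both other compounds is beyond the scatter: a 10-fold higher number from compound 1 to compound 2 (1.00 log units; beyond the scatter), and a 19-fold lower number from compound 2 to compound 3 (1.27 log units; beyond the scatter). Compound 1 and compound 3, by contrast, cannot be told apart: a 1.9-fold lower number from compound 1 to compound 3 (0.27 log units; within the scatter).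

The compound still to be measured, compound 4 `CCCn1c(=O)n(CC(C)=O)c(=O)c2[nH]cnc21`, differs from compound 2 in one place: acetyl in place of carbamoylmethyl on a saturated chain carbon bound to an aromatic nitrogen. The group that enters has no hydrogen-bond donor and one heavy atom fewer than the group that leaves, while it keeps a carbonyl as acceptor.

Both measured steps that touch the carbamoyl bear on this change. Adding carbamoyl to the ethyl chain cost a modest amount, and exchanging it for methoxy recovered that and more. Removing the carbamoyl's donor and nitrogen while retaining a carbonyl is expected to move compound 4 part of the way back toward compound 1 and compound 3 in this assay, so a step of a 4.4-fold lower number from compound 2 to compound 4 (0.64 log units; beyond the scatter) is expected. Compound 4 is therefore estimated at 3000 nM in this assay, with a likely range from 1000 nM to 9000 nM.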

Compound 4, half-maximal effective concentration: 14900 nM
For compound 4 the middle estimate is 5.0-fold (0.70 log units) below the measured one; measured number outside the range, above it.
By their numbers in this assay, from the lowest: compounds 3 and 1 (each within the scatter of the next); then compounds 2 and 4 (each within the scatter of the next).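

In this assay, acetyl in place of carbamoylmethyl on a saturated chain carbon bound to an aromatic nitrogen gives a 1.1-fold higher number from compound 2 to compound 4 (0.06 log units; within the scatter) and so leaves the two compounds together, even though the amide hydrogen and the nitrogen are gone. The hydrogen-bond donor is therefore not required for this high number: compound 4 has none, yet the steps of an 11-fold higher number from compound 1 to compound 4 (1.06 log units; beyond the scatter) and a 21-fold higher number from compound 3 to compound 4 (1.33 log units; beyond the scatter) both lie beyond the scatter. Across the four compounds, the two groups with a carbonyl, carbamoylmethyl and acetyl, go with the higher numbers and methyl and methoxymethyl with the lower numbers, and no compound shown goes against this. Nothing at hand explains this grouping.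

From the compounds shown here alone, it remains open whether the carbonyl itself matters here, which a hydroxyl group on the same chain in place of the acetyl carbonyl could test. Going by these compounds, it is also open whether a carboxylic acid, an amine or a longer chain ending in a ketone at this place would fall with compound 2 and compound 4 or with compound 1 and compound 3.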